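Cyclohexanone bis-benzylidene series: cytotoxicity notes

A few compounds are considered here, and "the series" means these few. Any claim that something is new, unique, unknown or untested is made for them only; others in the source may bear on it.

Compound 1 `CN(C)c1ccc(/C=C2\CCC/C(=C\c3cccc([N+](=O)[O-])c3)C2=O)cc1` gives > 400000 nM in an ADME assay on HPLF cells (Homo sapiens) for cytotoxicity, with a stated time of 24 h (on this read-out higher numbers stand for lower toxicity in this test and lower numbers for higher toxicity in this test), which is a limit of the measurement and not a number. Compound 2 `Cc1ccc(/C=C2\CCC/C(=C\c3cccc([N+](=O)[O-])c3)C2=O)cc1` gives > 400000 nM in this assay, again a limit. Compound 3 `CN(C)c1ccc(/C=C2\CCC/C(=C\c3ccc([N+](=O)[O-])cc3)C2=O)cc1` gives > 400000 nM in this assay, also a limit.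

All three measured values sit at the same point, (the limit of > 400000 nM in this assay, at which 3 of the 3 values shown sit). The step that the two limits leave unreadable from compound 1 to compound 2 is therefore unreadable, as is a step that the two limits leave unreadable from compound 1 to compound 3. The change from compound 1 to compound 2 is methyl in place of dimethylamino on an aromatic carbon. The two cores differ as 4-nitrophenyl in place of 3-nitrophenyl on a double-bonded chain carbon bound to a double-bonded ring carbon.

Compound 4 `Cc1ccc(/C=C2\CCC/C(=C\c3ccc([N+](=O)[O-])cc3)C2=O)cc1` has not been measured in this assay. The change from compound 3 to compound 4 is methyl in place of dimethylamino on an aromatic carbon. Going by the values given here, it is the same change as the one made from compound 1 to compound 2, and it is made on the core of compound 3 rather than that of compound 1.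

The expected step is a step that the limit leaves unreadable from compound 3 to compound 4, which is only a guess in size. This expectation rests on compound 1 and compound 2, whose step that the two limits leave unreadable from compound 1 to compound 2 sits at the limit (the limit of > 400000 nM in this assay, at which 3 of the 3 values shown sit), and on compound 3 sitting at the same limit (the limit of > 400000 nM in this assay, at which 3 of the 3 values shown sit). Compound 4 is expected to give 600000 nM in this assay, most likely again reported only as a limit, with a plausible range from 200000 nM to 3000000 nM.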

Compound 4, half-maximal cytotoxic concentration: 348000 nM
Estimate against measurement, compound 4: 1.7-fold (0.24 log units) above; the measured number falls inside the stated range.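

Methyl in place of dimethylamino on an aromatic carbon gives an at least 1.1-fold lower number from compound 3 to compound 4 (0.06 log units; that floor lies within the scatter) in this assay, and since the starting value is a limit, this is only a floor on the step. Because that floor lies within the scatter, the result neither establishes nor excludes a real difference, although it does make the change the only one here with any readable size. The same change on the core of compound 1 cannot be read, nor can the step between the two cores, so nothing shows that the change carries from one core to the other with the same size, or with a different one, and most of the series rests on a single ceiling: the limit of > 400000 nM in this assay, at which 3 of the 4 values shown sit.

Compound 4 is the only compound shown with a number rather than a limit, so it remains open whether the 4-methylphenyl group on the core of compound 1 would also give a number in this assay, and how far under the limit such values would fall. Also open, on these data alone, is how other groups on that aromatic carbon, such as a carboxylic acid, a primary amine or a longer alkyl chain, would read on either core.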